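Notes on a chloro substitution within the series

The compounds below may be only part of what the source reports. "The series", "measured", "known", "first", "only" and "open" are said of these compounds alone.

Measured so far:
compound 1, `Cc1nc(-c2ccc(Cl)cc2)sc1C(=O)CSc1nc(-c2ccc(Cl)c(Cl)c2)c(C#N)c(=O)[nH]1`, 93.9%
compound 2, `Cc1nc(-c2ccccc2)sc1C(=O)CSc1nc(-c2ccccc2)c(C#N)c(=O)[nH]1`, 77.5%
compound 3, `COc1ccc(-c2nc(SCC(=O)c3sc(-c4ccccc4)nc3C)[nH]c(=O)c2C#N)cc1OC`, 21.4%

In a functional assay on U-87MG ATCC cells for antiproliferative activity against U-87 MG (Homo sapiens), read by MTT assay, with a stated time of 48 h, tested at 50 uM (a higher number here means a weaker effect of the compound at the concentration tested, a lower number a stronger effect), compound 2 stands second highest of the three numbers, with compound 1 above it beyond the scatter and compound 3 far below it. Among the measured compounds shown here, the only single-place step measured concerns the other aromatic ring: a number 56.1 percentage points lower from compound 2 to compound 3 (beyond the scatter). Compound 4, `Cc1nc(-c2ccc(Cl)cc2)sc1C(=O)CSc1nc(-c2ccccc2)c(C#N)c(=O)[nH]1`, is not yet measured. It differs from compound 2 by chloro in place of hydrogen on an aromatic carbon. For the measured compounds named here, no measured pair isolates this change. Compound 1 carries the same chloro together with a second alteration on the other ring and gives 93.9%, while compound 2 gives 77.5%; that comparison is the only pointer and does not separate the two changes. For compound 4 a small upward step is expected, a number 7.5 percentage points higher from compound 2 to compound 4 (within the scatter), possibly within the scatter. Compound 4 is therefore estimated at 85%, with a range from 65% to 100%.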

Compound 4, a percentage reported as activity, at one concentration (the size of the read-out at that concentration, not a potency): 41.6%
Beside the measured number, compound 4's estimate is 43.4 percentage points above it; measured number below the stated range.
By their numbers in this assay, from the lowest: compound 3; then compound 4; then compound 2; then compound 1.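

In this assay, 4-chlorophenyl in place of phenyl acts on its own as a strengthening change at this position (a number 35.9 percentage points lower from compound 2 to compound 4 (beyond the scatter)), which compound 1, with its second alteration, could not show. With this chloro kept, the other ring also matters (a number 52.3 percentage points lower from compound 1 to compound 4 (beyond the scatter)), so the weak result of compound 1 goes with its 3,4-dichlorophenyl and does not reflect the 4-chlorophenyl, whose single step points the other way. Nothing available gives a reason for either step.

The compounds shown leave open whether the gain is specific to chloro or would also appear with a bromo, methoxy or amino group at this place on the ring. They also leave open whether 4-chlorophenyl and 3,4-dimethoxyphenyl, present together in one compound, would add up.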